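The source may hold more compounds than are shown below. What is called first, only, known or untested is meant among the compounds shown, and "the series" means these compounds.

Measured so far:
compound 1 `O=C(NNC(=O)c1cc([N+](=O)[O-])c[nH]1)Nc1ccc(Br)cc1` — 378000 nM
compound 2 `COc1ccc(OC)c(NC(=O)NNC(=O)c2cc([N+](=O)[O-])c[nH]2)c1` — 333000 nM
compound 3 `O=C(NNC(=S)Nc1ccc([N+](=O)[O-])cc1)c1cc([N+](=O)[O-])c[nH]1` — 529000 nM

In an ADME assay on Vero cells (Chlorocebus sabaeus) for cytotoxicity, read by MTT assay, with a stated time of 72 h (a lower number here means a stronger inhibitor, a higher number a weaker inhibitor), compound 1 gives 378000 nM. Its number lies between those of compound 2 and compound 3, and both neighbours fall within the usual scatter of it, so the three measured compounds show no separation in this assay. All three share the same core, and nothing among them isolates the effect of a single change.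

Compound 4 `O=C(NNC(=O)c1cc([N+](=O)[O-])c[nH]1)Nc1ccccc1` differs from compound 1 in one place: hydrogen in place of bromo on an aromatic carbon. Among the measured compounds shown here, no measured pair shows such a step, so the expectation rests on the flat spread of the three values. The step from compound 1 to compound 4 is expected to be small, a 1.1-fold higher number from compound 1 to compound 4 (0.05 log units; within the scatter), with no direction beyond the scatter. Compound 4 is estimated at 420000 nM, in a range from 200000 nM to 850000 nM.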

Compound 4, half-maximal inhibitory concentration: 357000 nM
Estimate against measurement, compound 4: 1.2-fold (0.07 log units) above; low and high end bracket the measured number.
By their numbers in this assay, from the lowest: compounds 2, 4, 1 and 3 (each within the scatter of the next).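

The change from 4-bromophenyl to phenyl gives the series its first comparison in one place: in this assay there is a 1.1-fold lower number from compound 1 to compound 4 (0.02 log units; within the scatter), so on this aromatic carbon, para to a large group, bromo and hydrogen are not separated. No measurement shown here explains this result.

Going by these compounds, it remains open whether an amine or a carboxylic acid on the same carbon would also stay within the scatter. The compounds shown also leave open whether a change at any other place on the shared core would separate from compound 1.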